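Oxygen-linked side chain variation and agonist potency

A few compounds are considered here, and "the series" means these few. Any claim that something is new, unique, unknown or untested is made for them only; others in the source may bear on it.

Measured so far:
compound 1, `O=c1[nH]/c(=N\OCCCc2ccccc2)ccn1[C@@H]1O[C@H](COP(=O)(O)OP(=O)(O)OP(=O)(O)O)[C@@H](O)[C@H]1O`, 740 nM
compound 2, `CCO/N=c1/ccn([C@@H]2O[C@H](COP(=O)(O)OP(=O)(O)OP(=O)(O)O)[C@@H](O)[C@H]2O)c(=O)[nH]1`, 877 nM
not yet measured: compound 3, `O=c1[nH]/c(=N\OCc2ccccc2)ccn1[C@@H]1O[C@H](COP(=O)(O)OP(=O)(O)OP(=O)(O)O)[C@@H](O)[C@H]1O`

Among the measured compounds shown here, in an in vitro functional assay on 1321-N1 cells for agonist activity at P2Y purinoceptor 6 (Homo sapiens), read by scintillation proximity assay and inositol phosphate accumulation, with a stated time of 30 min (on this read-out lower numbers stand for an effect already at smaller amounts and higher numbers for an effect only at larger amounts of compound), compound 2 gives the highest of the two numbers so far, but its only neighbour, compound 1, lies within the scatter: the step of a 1.2-fold higher number from compound 1 to compound 2 (0.07 log units; within the scatter), hydrogen in place of benzyl on a saturated chain carbon two bonds along the chain from an oxygen, changes the number hardly at all. On these two numbers compound 2 and compound 1 are indistinguishable in this assay.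

Compound 3 differs from compound 2 by phenyl in place of methyl on a saturated chain carbon bound to an oxygen on an unsaturated carbon; read one bond further out, ethoxy becomes benzyloxy. For the measured compounds named here, the only measured step that bears on this is the one from compound 1 to compound 2, where adding or removing the aromatic ring at the end of the chain stayed within the scatter. Going by the values given here, a shorter chain between the oxygen and the ring has no measured precedent here, so the expectation rests on that single step: for compound 3 a step of a 1.2-fold lower number from compound 2 to compound 3 (0.07 log units; within the scatter), none beyond the scatter, is expected in this assay. The estimate for compound 3 is 750 nM, with a range from 350 nM to 1600 nM.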

Compound 3, half-maximal effective concentration: 230 nM
Estimate against measurement, compound 3: 3.3-fold (0.51 log units) above, outside the stated range (below it).
By their numbers in this assay, from the lowest: compound 3; then compounds 1 and 2 (each within the scatter of the next).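

In this assay, the side chain position is more sensitive than the earlier compounds suggested: phenyl in place of methyl on a saturated chain carbon bound to an oxygen on an unsaturated carbon gives a 3.8-fold lower number from compound 2 to compound 3 (0.58 log units; beyond the scatter), a modest step beyond the scatter, while a 1.2-fold higher number from compound 1 to compound 2 (0.07 log units; within the scatter) had shown no clear difference. The presence of a phenyl group alone therefore does not set the number, since compound 1 also carries that ring but remains within the scatter of compound 2, and a 3.2-fold lower number from compound 1 to compound 3 (0.51 log units; beyond the scatter) separates the benzyloxy group from the longer chain of compound 1. No supporting data are available to explain this difference between the side chains.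

On these data alone, with only three side chains, the shape of the relationship between chain length and this assay remains open, including whether phenethyloxy would fall with benzyloxy or with the longer chain of compound 1. Also open, as far as these compounds go, is whether the lower number of compound 3 persists with a chlorophenyl, methoxyphenyl or pyridyl group in place of the phenyl group, or with an amine or a carboxylic acid at the end of the chain.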